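A Chloro-Anilide Variant of a Quinoline Ether Series

A few compounds are considered here, and "the series" means these few. Any claim that something is new, unique, unknown or untested is made for them only; others in the source may bear on it.

Three compounds sharing one core have been characterised in a physicochemical assay for lipophilicity, read by HPLC, in phosphate buffer, measured as chromatographic lipophilicity, at pH 7.4; on this read-out higher numbers stand for higher lipophilicity and lower numbers for lower lipophilicity. Compound 1 `COc1ccc2nc(C)cc(OCc3ccc4ccccc4n3)c2c1` gives 5.48, compound 2 `COc1ccc2nc(C)cc(OCC(=O)Nc3c(C)cccc3C)c2c1` gives 4.55, and compound 3 `COc1ccc2nc(C)cc(OCC(=O)Nc3cc(OC)c(OC)c(OC)c3)c2c1` gives 3.95. On these numbers compound 2 stands second highest of the three: it lies below compound 1 and above compound 3, and both of those gaps exceed the usual scatter of this assay.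

Compound 4 `COc1ccc2nc(C)cc(OCC(=O)Nc3ccc(Cl)cc3)c2c1` has not yet been measured. It differs from compound 2 in a single place: 4-chlorophenyl in place of 2,6-dimethylphenyl on an amide-type nitrogen. Among the compounds with values here, no measured pair in this set isolates that change, so its effect has to be anticipated rather than read off.

Starting from compound 2 at 4.55, the account expects a modest decrease in this assay, a step of about a number 0.35 log units lower from compound 2 to compound 4 (beyond the scatter), small but likely beyond the scatter. Compound 4 is accordingly estimated at 4.2, with a plausible range from 3.8 to 4.6.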

Compound 4, distribution coefficient: 5.15
Beside the measured number, compound 4's estimate is 0.95 log units below it, and the stated range ends below it.
By their numbers in this assay, from the lowest: compound 3; then compound 2; then compound 4; then compound 1.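

In this assay, within the data shown here, the group on the amide-type nitrogen proves able to move the reading: 4-chlorophenyl in place of 2,6-dimethylphenyl gives a number 0.60 log units higher from compound 2 to compound 4 (beyond the scatter) in the first step here that isolates one change at this place. The entering group has 7 heavy atoms against 8 for the group it replaces, and the two match in hydrogen-bond donors, hydrogen-bond acceptors and net charge, so the number rises although the heavy-atom count falls. No measured evidence at hand accounts for the size or direction of this step.

A plain phenyl or a 4-methylphenyl on the same nitrogen would help separate the part played by the chlorine from the part played by the two methyl groups. As far as these compounds go, how a carboxylic acid or an amine on that aromatic ring would read in this assay also remains open.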